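Changing the aryl group of the benzamide: nitrile to halogens

This account rests on a few compounds, and the source may have more. Where it says the series, first, only, none or still open, it means among the compounds named here.

Compound 2 `CCOC(=O)c1sc(-c2cccc(NC(=O)c3ccccc3F)c2)nc1Nc1ccc(N2CCN(C)CC2)cc1`: 2000 nM in a functional assay on Ramos cells (Homo sapiens) for antiproliferative activity, read by CCK-8 assay, with a stated time of 72 h; a higher number here means a weaker inhibitor, a lower number a stronger inhibitor
Compound 3 `CCOC(=O)c1sc(-c2cccc(NC(=O)c3ccc(C#N)cc3)c2)nc1Nc1ccc(N2CCN(C)CC2)cc1`: 4280 nM in this assay
Compound 1 `CCOC(=O)c1sc(-c2cccc(NC(=O)c3ccc(F)cc3)c2)nc1Nc1ccc(N2CCN(C)CC2)cc1`: "not determined" (no result reported) in this assay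

Three compounds share a common core and differ only in the aryl group attached to the amide carbonyl. Compound 1 carries a 4-fluorophenyl there but has no reported number. Going by the values given here, of the two measured compounds, compound 3 gives the highest number, and the single measured step, a 2.1-fold higher number from compound 2 to compound 3 (0.33 log units; beyond the scatter), shows that moving from a 2-fluorophenyl to a 4-cyanophenyl weakened inhibition modestly.

Compound 4 `CCOC(=O)c1sc(-c2cccc(NC(=O)c3ccc(F)c(Cl)c3)c2)nc1Nc1ccc(N2CCN(C)CC2)cc1` is the next entry. Its change from compound 3 is 3-chloro-4-fluorophenyl in place of 4-cyanophenyl on a carbonyl carbon. Among the compounds with values here, no measured step covers this exact exchange, but the one step that exists, a 2.1-fold higher number from compound 2 to compound 3 (0.33 log units; beyond the scatter), suggests that a halogen-bearing phenyl was somewhat better than the nitrile-bearing one. On that basis compound 4 is expected to recover part of that loss, an estimated 1.7-fold lower number from compound 3 to compound 4 (0.23 log units; within the scatter). Compound 4 is therefore estimated at 2500 nM, with a range from 1000 nM to 6000 nM.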

Compound 4, half-maximal inhibitory concentration: 29200 nM
For compound 4 the middle estimate is 12-fold (1.07 log units) below the measured one; the whole stated range lies below it.
By their numbers in this assay, from the lowest: compound 2; then compound 3; then compound 4.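

In this assay the exchange gave a 6.8-fold higher number from compound 3 to compound 4 (0.83 log units; beyond the scatter) and, measured against the 2-fluorophenyl group, a 15-fold higher number from compound 2 to compound 4 (1.16 log units; beyond the scatter) in the same direction, which shows that this position tolerates much larger differences than the earlier pair revealed. Halogen on the phenyl ring does not by itself keep the number low: compound 2 and compound 4 both carry halogen yet stand at opposite ends of the series, with the nitrile-bearing compound 3 lying between them. Nothing available here accounts for this difference.

The compounds shown leave open whether the loss follows from the chlorine itself or from the combination of chlorine and fluorine, since no phenyl carrying chlorine alone appears among them. They also leave open how an unsubstituted phenyl, or a phenyl bearing an amine or a carboxylic acid, would behave here.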